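Methoxy to (Oxan-4-yl)oxy: Estimating Compound 3

The source may hold more compounds than are shown below. What is called first, only, known or untested is meant among the compounds shown, and "the series" means these compounds.

Measured so far in a functional assay on CHO cells for antagonist activity at C-X-C chemokine receptor type 3 (Homo sapiens), read by GTPgammaS binding; a higher number here means a weaker inhibitor, a lower number a stronger inhibitor:
Compound 1, `CC(=O)c1cccc(NC(=O)NC2CCN(CC3=CC[C@H]4C[C@@H]3C4(C)C)CC2)c1`: 258 nM
Compound 2, `COc1cccc(NC(=O)NC2CCN(CC3=CC[C@H]4C[C@@H]3C4(C)C)CC2)c1`: 429 nM

Compound 2 carries the higher of these two numbers, but the step of a 1.7-fold higher number from compound 1 to compound 2 (0.22 log units; within the scatter) lies within the scatter, so on these numbers the two compounds cannot be told apart. Compound 3, `CC1(C)[C@H]2CC=C(CN3CCC(NC(=O)Nc4cccc(OC5CCOCC5)c4)CC3)[C@@H]1C2`, has not yet been measured. It differs from compound 2 by oxan-4-yl in place of methyl on an oxygen on an aromatic ring. Among the measured compounds shown here, no measured step bears directly on this change: the single step known swaps one group on an aromatic carbon for another and moves the number little, and nothing shows what enlarging the group on the oxygen on the aromatic ring does. With that gap, the expectation is a step of a 1.0-fold higher number from compound 2 to compound 3 (0.02 log units; within the scatter), estimated to stay close to the scatter and with wide uncertainty. Compound 3 is therefore estimated at 450 nM, with a range from 150 nM to 1400 nM.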

Compound 3, inhibition constant: 191 nM
Estimate against measurement, compound 3: 2.4-fold (0.37 log units) above, and the stated range covers the measured number.
By their numbers in this assay, from the lowest: compounds 3, 1 and 2 (each within the scatter of the next, the first and the last beyond it).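

In this assay the oxygen on the aromatic ring accepts a much larger group with no loss of inhibition: oxan-4-yl in place of methyl gives a 2.2-fold lower number from compound 2 to compound 3 (0.35 log units; beyond the scatter) as a modest step, the only one so far beyond the scatter. The earlier pair showed only a swap on an aromatic carbon, whereas this result shows that the group on this oxygen can grow from one heavy atom to six, including a six-membered non-aromatic ring. Set against acetyl on the aromatic carbon, (oxan-4-yl)oxy gives a 1.4-fold lower number from compound 1 to compound 3 (0.13 log units; within the scatter) and so cannot be told apart from it.

From the compounds shown here alone, it remains open whether the ring oxygen matters, which cyclohexyl on the same oxygen would test, and how an amine-bearing piperidin-4-yl or an open butyl chain would behave. No measurement available here explains the step.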